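Swapping the aryl ether tail: a nitrile for trifluoromethyl

The source may report more compounds than this note shows. Statements on the series, on what has been measured and on what is new or still open speak of the compounds shown alone.

Of the compounds shown here, three sharing one core have been measured in an assay on cells for inhibition of Voltage-dependent T-type calcium channel subunit alpha-1H (Homo sapiens), read by FLIPR and calcium flux, with stated times of 600 s and 300 s; a higher number here means a weaker inhibitor, a lower number a stronger inhibitor. Compound 1 `CN(Cc1ccc(OCCCN)cc1)c1nc2ccc(Oc3ccc(C#N)cc3)cc2s1` gives 328000 nM. Compound 2 `CN(Cc1ccc(OCCCNC(=N)N)cc1)c1nc2ccc(Oc3ccccc3)cc2s1` gives 498000 nM, and compound 3 `CN(Cc1ccc(OCCCNC(=N)N)cc1)c1nc2ccc(Oc3cccc(C(F)(F)F)c3)cc2s1` gives 771000 nM. Compound 3 therefore carries the highest of the three numbers; its nearest neighbour is compound 2, while the gap to compound 1 lies beyond the scatter. Among the compounds with values here, the only single change measured so far is a 1.5-fold higher number from compound 2 to compound 3 (0.19 log units; within the scatter), a step that stays within the scatter.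

The next step leads to compound 4 `CN(Cc1ccc(OCCCNC(=N)N)cc1)c1nc2ccc(Oc3ccc(C#N)cc3)cc2s1`, and the change is 4-cyanophenyl in place of 3-(trifluoromethyl)phenyl on an oxygen on an aromatic ring. Within the data shown here, no measured step covers this exact swap. Compound 1 already bears 4-cyanophenyl, though on a different amine chain, and its value sits well under that of compound 3. Given that compound 1 and compound 2 both lie below compound 3, compound 4 is expected to show a 1.9-fold lower number from compound 3 to compound 4 (0.28 log units; within the scatter). For compound 4 the estimate is 400000 nM, with a range from 150000 nM to 1000000 nM.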

Compound 4, half-maximal inhibitory concentration: 153000 nM
Estimate against measurement, compound 4: 2.6-fold (0.42 log units) above; low and high end bracket the measured number.
By their numbers in this assay, from the lowest: compound 4; then compounds 1, 2 and 3 (each within the scatter of the next, the first and the last beyond it).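

In this assay, the aryl group on this oxygen can shift the number beyond the scatter, which the earlier trifluoromethyl step did not show: 4-cyanophenyl in place of 3-(trifluoromethyl)phenyl gives a 5.0-fold lower number from compound 3 to compound 4 (0.70 log units; beyond the scatter), and cyano in place of hydrogen on the aromatic carbon gives a 3.3-fold lower number from compound 2 to compound 4 (0.51 log units; beyond the scatter). The amine end also counts with 4-cyanophenyl held fixed, as the added group on the amine nitrogen gives a 2.1-fold lower number from compound 1 to compound 4 (0.33 log units; beyond the scatter), leaving compound 4 the strongest inhibitor of the four. Nothing at hand explains why these changes lower the number.

The compounds shown leave open whether a methoxy group or a carboxylic acid on this aromatic ring would match the nitrile. They also leave open how a longer chain to the terminal nitrogen would affect the number.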